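Chain change from compound 3 to compound 4

This account rests on a few compounds, and the source may have more. Where it says the series, first, only, none or still open, it means among the compounds named here.

In a functional assay on the whole organism for inhibition, with Rattus norvegicus as the target (on this read-out lower numbers stand for an effect already at smaller amounts and higher numbers for an effect only at larger amounts of compound), compound 1 (`CS(=O)(=O)c1ccc2c(c1)c(C1CCN(CCN3CCNC3=O)CC1)cn2-c1ccc(F)cc1`) gives 54 umol/kg, compound 2 (`Cc1ccc2c(c1)c(C1CCN(CCN3CCNC3=O)CC1)cn2-c1ccc(F)cc1`) gives 0.0083 umol/kg and compound 3 (`CN1CCN(CCN2CCC(c3cn(-c4ccc(F)cc4)c4ccc(Cl)cc34)CC2)C1=O`) gives 0.021 umol/kg. Compound 3 therefore holds the middle of the three numbers, higher than compound 2 beyond the scatter and far lower than compound 1.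

Compound 4 (`O=C1NCCN1CCCN1CCC(c2cn(-c3ccc(F)cc3)c3ccc(Cl)cc23)CC1`) differs from compound 3 as follows: (2-oxoimidazolidin-1-yl)methyl in place of 3-methyl-2-oxoimidazolidin-1-yl on a saturated chain carbon, two bonds along the chain from an amine nitrogen in a ring. The ring methyl is gone, and a 2-(3-methyl-2-oxoimidazolidin-1-yl)ethyl becomes a 3-(2-oxoimidazolidin-1-yl)propyl.

Within the data shown here, the only measured step, a 6500-fold lower number from compound 1 to compound 2 (3.81 log units; beyond the scatter), lies on an aromatic carbon and leaves the chain untouched. It shows how far this read-out can move, but says nothing direct about this change. Among the measured compounds shown here, no measured step covers chain length or the ring methyl. Compound 2 lacks that methyl and still gives 0.0083 umol/kg, so a large rise is not expected.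

A modest rise is expected, estimated as a 2.4-fold higher number from compound 3 to compound 4 (0.38 log units; beyond the scatter). The estimated value for compound 4 is 0.05 umol/kg, with an expected range of 0.008 umol/kg to 0.3 umol/kg.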

Compound 4, dose for half-maximal effect: 1.8 umol/kg
Beside the measured number, compound 4's estimate is 36-fold (1.56 log units) below it, outside the stated range (above it).
By their numbers in this assay, from the lowest: compound 2; then compound 3; then compound 4; then compound 1.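

In this assay, the chain position proves highly sensitive: an 86-fold higher number from compound 3 to compound 4 (1.93 log units; beyond the scatter), with the core of compound 3 left intact, so a large step is no longer confined to the aromatic carbon. The change is a double one, as the ring methyl goes and the ethyl link becomes a propyl link, and this single step cannot divide its size between those two parts. No measured data bear on the reason for this step.

As far as these compounds go, it remains open how a 3-(3-methyl-2-oxoimidazolidin-1-yl)propyl group on the core of compound 3 would read, which would isolate the chain length from the ring methyl. Also open, from the compounds shown here alone, is whether a still longer chain, such as 4-(2-oxoimidazolidin-1-yl)butyl, would continue the direction of this step or reverse it.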